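Aminopyrimidine amine swap on the shared core

This account rests on a few compounds, and the source may have more. Where it says the series, first, only, none or still open, it means among the compounds named here.

Measured so far:
compound 1 `O=C1N([C@H](CO)c2cccc(Cl)c2)Cc2cc(-c3nc(NC4CCOCC4)ncc3Cl)cn21` — 104 nM
compound 2 `Cn1nccc1Nc1nccc(-c2cn3c(n2)CN([C@H](CO)c2cccc(Cl)c2)C3=O)n1` — "not active" (no number reported)

Among the compounds with values here, compound 1 carries the only number in a functional assay on COLO 205 cells (Homo sapiens) for antiproliferative activity, read by luminescence, with a stated time of 72 h (a lower number here means a stronger inhibitor, a higher number a weaker inhibitor), in this set; the one other entry, compound 2, came back without a value, so compound 1 cannot be placed relative to anything else by this assay. In this assay compound 1 gives 104 nM.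

Compound 3 `C[C@@H](CO)Nc1ncc(Cl)c(-c2cc3n(c2)C(=O)N([C@H](CO)c2cccc(Cl)c2)C3)n1` differs from compound 1 in one place: 1-(hydroxymethyl)ethyl in place of oxan-4-yl on a nitrogen on an aromatic ring. The change keeps the amino link on the aromatic ring and trades a ring for an open chain carrying a further hydrogen-bond donor. Within the data shown here, no measured pair in this set isolates a change of this kind, so no step is known to anchor it.

Expectation: a change of this size on an amine substituent, with no measured precedent here, is estimated to move this assay little, and the step from compound 1 to compound 3 is expected to fall near or only slightly beyond the scatter, if anything toward weaker inhibition, a 1.4-fold higher number from compound 1 to compound 3 (0.16 log units; within the scatter). Compound 3 is therefore estimated at 150 nM, with a range of 50 nM to 450 nM.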

Compound 3, half-maximal inhibitory concentration: 81 nM
Beside the measured number, compound 3's estimate is 1.9-fold (0.27 log units) above it, within the range that was stated.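

In this assay, 1-(hydroxymethyl)ethyl in place of oxan-4-yl on a nitrogen on an aromatic ring gives a 1.3-fold lower number from compound 1 to compound 3 (0.11 log units; within the scatter). This position therefore tolerates the open chain, with its hydrogen-bond donor and defined stereocentre, in place of the six-membered non-aromatic ring, with no step beyond the scatter. Within the data shown here, until now compound 1 carried the only number, so nothing showed whether a value in this range depended on the oxan-4-yl ring; for this one open chain, it does not, although no measurement available here explains why the two groups read alike.

Going by these compounds, the read-outs in this assay for the opposite configuration of the 1-(hydroxymethyl)ethyl group, for a plain isopropyl group without the hydroxyl, and for a longer chain ending in an amine or a carboxylic acid remain open. A single step within the scatter sets no trend for this position, and compound 2 offers no number to read against it.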